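A few compounds are considered here, and "the series" means these few. Any claim that something is new, unique, unknown or untested is made for them only; others in the source may bear on it.

Measured so far:
- Compound 1, `Cc1cc(NC(=O)Nc2ccc(C(=O)O)cc2)c2ccccc2n1`: > 25000 nM in an ADME assay on BJ cells (Homo sapiens) for cytotoxicity, with a stated time of 72 h; a lower number here means that less compound is needed, a higher number that more compound is needed for the effect
- Compound 2, `Cc1cc(NC(=O)Nc2ccc(C(=O)O)c(O)c2)c2ccccc2n1`: > 25000 nM
- Compound 3, `Cc1cc(NC(=O)Nc2ccc(Cl)c(Cl)c2)c2ccccc2n1`: 23000 nM

The value of compound 1 is a limit of the assay, not a number. The value of compound 2 is also such a limit, so that the limit of > 25000 nM in this assay, at which 2 of the 3 values shown sit, is where both sit. Compound 3 is the only one of the three with a number, and in this assay compound 3 gives 23000 nM. Among the compounds with values here, the one step between measured compounds that differ in a single place, a step that the two limits leave unreadable from compound 1 to compound 2, has a size that cannot be read because both ends are limits.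

Compound 4, `Cc1cc(NC(=O)Nc2ccc(OC(F)(F)F)cc2)c2ccccc2n1`, has not yet been measured. It differs from compound 1 in one place: trifluoromethoxy in place of carboxy on an aromatic carbon. Within the data shown here, no measured step changes the same part of the shared core, so none of the measured steps bears directly on this change. The measured values give only a coarse picture: compound 3 sits close to the limit at which the others are reported. On that basis no step beyond the usual scatter is expected in either direction.

For compound 4 the estimate in this assay is 25000 nM, within 10000 nM to 60000 nM, which means an expected step of a number no higher from compound 1 to compound 4 (the limit leaves the size open).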

Compound 4, half-maximal effective concentration: 25000 nM
For compound 4 middle estimate and measured number coincide at the digits printed; the measured number falls inside the stated range.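

In this assay compound 1 gives > 25000 nM, which is a limit of the assay and not a number. Where the earlier step only put hydroxy on an aromatic carbon that held hydrogen, this change replaces the carboxy group itself, para to a large group: trifluoromethoxy, with 0 hydrogen-bond donors and 5 heavy atoms, takes the place of a group with 1 hydrogen-bond donor and 3 heavy atoms, and compound 4 gives a number, 25000 nM, so that the change reads as a number no higher from compound 1 to compound 4 (the limit leaves the size open). The comparison therefore fixes a direction at this position but no size, and neither this step nor the earlier one can be read, because at least one end of each sits at a limit: the limit of > 25000 nM in this assay, at which 2 of the 4 values shown sit.

The compounds shown leave open how an amine or a longer chain, such as a propoxy group, would read at this same place in this assay. With a single replacement for the carboxy group here, they also cannot show whether any group at this position moves the value by more than the usual scatter.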